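Swapping Furan-2-yl for 3-Nitrophenyl: Expected Cytotoxicity

This account rests on a few compounds, and the source may have more. Where it says the series, first, only, none or still open, it means among the compounds named here.

Three compounds were measured in an ADME assay on HEK293 cells (Homo sapiens) for cytotoxicity, read by CellTiter-Glo and resazurin assay, with a stated time of 72 h (a lower number here means that less compound is needed, a higher number that more compound is needed for the effect), and each gave only a limit of the assay rather than a number:

compound 1 `CC(C)N(Cc1cccc(OCCCCCC(=O)O)c1)C(=O)c1ccc(-c2ccco2)cc1` — > 26000 nM, a limit
compound 2 `CCOc1cccc(-c2ccc(C(=O)N(Cc3cccc(OCCCCCC(=O)O)c3)C(C)C)cc2)c1` — > 20800 nM, a limit
compound 3 `CC(C)N(Cc1cccc(OCCCCCC(=O)O)c1)C(=O)c1ccc(-c2cccc(C(F)(F)F)c2)cc1` — > 26000 nM, a limit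

Compound 1 therefore stands at a limit in this assay, not at a measured number. Two of the three values sit at the limit of > 26000 nM in this assay, at which 2 of the 3 values shown sit, and one sits at the limit of > 20800 nM in this assay, at which 1 of the 3 values shown sits.

Compound 4 `CC(C)N(Cc1cccc(OCCCCCC(=O)O)c1)C(=O)c1ccc(-c2cccc([N+](=O)[O-])c2)cc1` differs from compound 1 by 3-nitrophenyl in place of furan-2-yl on an aromatic carbon. The measured steps that bear on this change are a step that the two limits leave unreadable from compound 1 to compound 2 and a step that the two limits leave unreadable from compound 1 to compound 3, each of which replaces the same group at the same place as the change to compound 4. Neither step has a readable size: both of its ends are limits. The remaining step, a step that the two limits leave unreadable from compound 2 to compound 3, is unreadable for the same reason. With no readable step in either direction, nothing beyond the scatter can be expected in this assay, and the most likely outcome for compound 4 is again a limit. Compound 4 is expected at about 26000 nM, with a range from 15000 nM to 60000 nM. This expectation corresponds to an estimated step of a number no higher from compound 1 to compound 4 (the limit leaves the size open).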

Compound 4, half-maximal effective concentration: > 26000 nM
Compound 4: only a limit was reported; the forecaster's own chance of this, stated with the estimate: 85%; the middle value sits exactly at the limit.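

In this assay compound 4 gives > 26000 nM, a limit and not a number. Among the compounds shown here, compound 1, compound 2 and compound 3 also stand at limits, so no step between compound 4 and any of them can be read. The compounds shown leave open how much of each is needed for the effect, and whether the group exchanged on the aromatic carbon changes that amount at all.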